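Trifluoromethyl in place of chloro: compound 3 to compound 4

A few compounds are considered here, and "the series" means these few. Any claim that something is new, unique, unknown or untested is made for them only; others in the source may bear on it.

Of the compounds shown here, three sharing one core have been measured in a functional assay on J774 cells (Mus musculus) for cytotoxicity, read by resazurin assay; a lower number here means a stronger inhibitor, a higher number a weaker inhibitor. Compound 1 (`OCCCCCC(O)c1ccc(-c2ccc(F)cc2)cc1`) gives 18000 nM, compound 2 (`CSc1ccc(-c2ccc(C(O)CCCCCO)cc2)cc1`) gives 24000 nM and compound 3 (`OCCCCCC(O)c1ccc(-c2ccc(Cl)cc2)cc1`) gives 17000 nM. These values lie within the scatter of each other, so compound 3 cannot be separated from compound 1 or compound 2.

Compound 4 (`OCCCCCC(O)c1ccc(-c2ccc(C(F)(F)F)cc2)cc1`) has trifluoromethyl in place of chloro on an aromatic carbon of compound 3: trifluoromethyl in place of chloro on an aromatic carbon. The three measured steps all exchange a group at this same place, and all are small: a 1.1-fold lower number from compound 1 to compound 3 (0.02 log units; within the scatter), a 1.3-fold higher number from compound 1 to compound 2 (0.12 log units; within the scatter) and a 1.4-fold lower number from compound 2 to compound 3 (0.15 log units; within the scatter). Across fluoro, chloro and methylsulfanyl, no exchange among these three compounds has moved the number beyond the scatter, and none of them goes against that. Trifluoromethyl itself has not yet been tested in this assay, so this remains an extension from three compounds only.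

No step beyond the scatter is expected, and no direction can be assigned. The estimated step is no change at the digits printed from compound 3 to compound 4 (within the scatter). Compound 4 is expected at 17000 nM. The expected range for this estimate runs from 9500 nM to 30000 nM.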

Compound 4, half-maximal inhibitory concentration: 13000 nM
Beside the measured number, compound 4's estimate is 1.3-fold (0.12 log units) above it; low and high end bracket the measured number.
By their numbers in this assay, from the lowest: compounds 4, 3, 1 and 2 (each within the scatter of the next).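

Trifluoromethyl brings 4 heavy atoms to the place where chloro has 1, on an aromatic carbon para to a large group, and in this assay this exchange still stays within the scatter (a 1.3-fold lower number from compound 3 to compound 4 (0.12 log units; within the scatter)). Going by these compounds alone, the same holds against the other two groups (a 1.4-fold lower number from compound 1 to compound 4 (0.14 log units; within the scatter); a 1.8-fold lower number from compound 2 to compound 4 (0.27 log units; within the scatter)), and the last of these, though the widest step at this position so far, is also within the scatter, so fluoro, chloro, methylsulfanyl and trifluoromethyl cannot be separated here and none of compounds 1 to 4 goes against that. No supporting measurement is available to explain this flat picture.

Still open is whether an amine or a carboxylic acid at this same aromatic carbon would give a step beyond the scatter, since all four groups shown leave the number in one narrow band. Also open, going by these compounds, is whether the number depends on the shared hydroxyl-bearing chain, for instance whether a longer chain on the core of compound 1 would move it.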